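Dienamide series: fluoro to dimethylamino on the aryl ring

This account rests on a few compounds, and the source may have more. Where it says the series, first, only, none or still open, it means among the compounds named here.

Measured so far:
compound 1 `O=C(/C=C/C=C/c1ccc(F)cc1)N1CCCCC1` 48.7%
compound 2 `CN(C)c1ccc(/C=C/C=C/C=C/C(=O)N2CCCCC2)cc1` 27.4%
compound 3 `O=C(/C=C/C=C/c1cc(O)c(O)c(O)c1)N1CCCCC1` 82.5%

Three piperidine amides carrying an aryl polyene have been measured in an assay for inhibition of Polyunsaturated fatty acid 5-lipoxygenase (Homo sapiens), read by spectrophotometry, tested at 20 uM; on this read-out lower numbers stand for less inhibition and higher numbers for more inhibition at the one concentration tested (going by the name of the read-out). Compound 1 stands second highest of the three: compound 2 gives a number that lies below it by more than the scatter, and compound 3 gives the highest number, above compound 1 by well more than the scatter. Going by the values given here, compound 2 carries a longer chain than compound 1 and compound 3, so no single-point step between any two measured compounds can be drawn.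

The next compound, compound 4 `CN(C)c1ccc(/C=C/C=C/C(=O)N2CCCCC2)cc1`, differs from compound 1 in one place: dimethylamino in place of fluoro on an aromatic carbon.

Among the compounds with values here, no step between measured compounds shows this change directly. Within the data shown here, the only other measured compound bearing the dimethylamino group is compound 2, which gives 27.4% in this assay, the lowest of the three numbers, though compound 2 also carries a longer chain. On that basis the step from fluoro to dimethylamino is expected to move inhibition downward, a number 16.7 percentage points lower from compound 1 to compound 4 (beyond the scatter), by an amount beyond the scatter. Compound 4 is therefore estimated at 32%, within a range of 15% to 52%.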

Compound 4, a percentage reported as inhibition, at one concentration (the size of the read-out at that concentration, not a potency): 13.4%
Compound 4: middle estimate off by 18.6 percentage points, on the high side, and the stated range ends above it.
By their numbers in this assay, from the lowest: compound 4; then compound 2; then compound 1; then compound 3.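

In this assay, going by these compounds alone, dimethylamino in place of fluoro on an aromatic carbon, para to a large group, gives the first direct one-place step: a number 35.3 percentage points lower from compound 1 to compound 4 (beyond the scatter), a large change. The result shows that inhibition at this concentration depends strongly on the group at this position, with the step from one heavy atom to three and the gain of one hydrogen-bond acceptor accompanying the lower reading, though this single pair cannot separate those two differences. No available evidence bears on what lies behind the step.

Still open, on these data alone, is whether the lower reading belongs to dimethylamino specifically or extends to other groups at this position, such as a primary amine, methoxy or chloro, any of which could help show whether heavy-atom count or the acceptor tracks with the change. Also open, as far as these compounds go, is how chain length acts on its own: a fluoro compound carrying the longer chain of compound 2 would give a one-place comparison with compound 1, and would show whether the large step seen here holds on a longer chain.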